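A few compounds are considered here, and "the series" means these few. Any claim that something is new, unique, unknown or untested is made for them only; others in the source may bear on it.

Measured compounds in a functional assay on DU-145 cells (Homo sapiens) for cytotoxicity, read by CCK-8 assay; a lower number here means a stronger inhibitor, a higher number a weaker inhibitor:
compound 1, `Oc1cccc(-c2cc(-c3ccco3)cc(-c3cccc(O)c3)n2)c1`; compound 1 gives 2150 nM
compound 2, `Oc1cccc(-c2cc(-c3ccoc3)cc(-c3cccc(O)c3)n2)c1`; compound 2 gives 1650 nM
compound 3, `Oc1cccc(-c2cc(-c3cccnc3)cc(-c3ccccc3O)n2)c1`; compound 3 gives 5580 nM

Compound 3 stands at the highest number of the three in this assay. Its nearest neighbour is compound 1, whose number is lower by an amount beyond the scatter, and compound 2 lies further below it. The one measured step among these compounds, a 1.3-fold lower number from compound 1 to compound 2 (0.11 log units; within the scatter), concerns a different change and does not bear on the move toward compound 4.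

Compound 4, `Oc1cccc(-c2cc(-c3cccnc3)cc(-c3cccc(O)c3)n2)c1`, differs from compound 3 in one place: 3-hydroxyphenyl in place of 2-hydroxyphenyl on an aromatic carbon. Compound 4 thereby carries the same two 3-hydroxyphenyl groups as compounds 1 and 2, with pyridin-3-yl where they carry a furanyl group. Within the data shown here, no measured pair tests this particular swap, so the expectation rests on the observation that compounds 1 and 2 both give lower numbers than compound 3. On that footing compound 4 is expected to move toward the range of compounds 1 and 2, a step estimated at a 2.0-fold lower number from compound 3 to compound 4 (0.30 log units; within the scatter), downward in this assay. Compound 4 is thus expected to give about 2800 nM, within a range from 1200 nM to 6500 nM, given the scatter and the absence of a directly comparable step.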

Compound 4, half-maximal inhibitory concentration: > 50000 nM
Compound 4 ended at the assay's limit; the forecaster's own chance of this, stated with the estimate: 5%; at least 17-fold (1.25 log units) between middle value and limit.
By their numbers in this assay, from the lowest: compounds 2 and 1 (each within the scatter of the next); then compound 3. At a limit, above all of these: compound 4.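

In this assay compound 4 stands at a limit of the assay, not at an exact number: the limit of > 50000 nM in this assay, at which 1 of the 4 values shown sits.

With pyridin-3-yl held constant, the location of the hydroxy group on the ring attached to the aromatic carbon next to the ring nitrogen proves decisive, as 3-hydroxyphenyl in place of 2-hydroxyphenyl gives an at least 8.9-fold higher number from compound 3 to compound 4 (0.95 log units; beyond the scatter), so of this pair only the 2-hydroxyphenyl compound reaches a measurable number. With both 3-hydroxyphenyl groups held constant, the remaining group also weighs heavily, as pyridin-3-yl in place of a furanyl group gives an at least 30-fold higher number from compound 2 to compound 4 (1.48 log units; beyond the scatter) and an at least 23-fold higher number from compound 1 to compound 4 (1.36 log units; beyond the scatter), so two 3-hydroxyphenyl groups alone do not secure a measurable number.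

The compounds shown leave open whether 2-hydroxyphenyl would also change the number when paired with furan-2-yl or furan-3-yl, so it remains unknown whether its effect depends on the pyridin-3-yl group. They also leave open whether a methoxy group or an amine in place of the hydroxy group on this ring would give a measurable number.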